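Swapping chloro for methoxy on the aryl of compound 1

The source may hold more compounds than are shown below. What is called first, only, known or untested is meant among the compounds shown, and "the series" means these compounds.

Compounds measured so far:
- compound 1, `COc1cc(/C=C/C(=O)c2cccc(-n3cc(-c4ccc(Cl)cc4)[nH]c3=O)c2)cc(OC)c1OC`, 10900 nM
- compound 2, `COc1cc(/C=C/C(=O)c2cccc(-n3cc(-c4ccccc4)[nH]c3=O)c2)ccc1O`, 1850 nM
- compound 3, `O=C(/C=C/c1cccc(O)c1)c1cccc(-n2cc(-c3ccc(Cl)cc3)[nH]c2=O)c1`, 3640 nM

In a functional assay on SK-MEL-28 cells (Homo sapiens) for inhibition (a lower number here means a stronger inhibitor of growth, a higher number a weaker inhibitor of growth), compound 1 gives the highest of the three numbers; compound 3 lies nearest to it and compound 2 furthest, both gaps reaching beyond the usual scatter. Compound 4, `COc1ccc(-c2cn(-c3cccc(C(=O)/C=C/c4cc(OC)c(OC)c(OC)c4)c3)c(=O)[nH]2)cc1`, has not been measured. It differs from compound 1 in one place: methoxy in place of chloro on an aromatic carbon. Going by the values given here, no measured pair isolates this exchange, so the data give no direct guide. The author expects, on that account, a step of a 1.6-fold lower number from compound 1 to compound 4 (0.19 log units; within the scatter) in this assay, most likely small and leaning toward a lower number, but not certainly beyond the scatter. Compound 4 is therefore estimated at 7000 nM, with a range from 2500 nM to 20000 nM.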

Compound 4, concentration for 50% growth inhibition: 2030 nM
The estimate for compound 4 lay 3.4-fold (0.54 log units) above the measured number; measured number below the stated range.
By their numbers in this assay, from the lowest: compounds 2, 4 and 3 (each within the scatter of the next); then compound 1.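

In this assay, methoxy in place of chloro on this aromatic carbon, para to a large group, gives a 5.4-fold lower number from compound 1 to compound 4 (0.73 log units; beyond the scatter) with the rest of the molecule unchanged. Going by these compounds alone, this pair is the first to isolate a single change, and it shows that growth inhibition here depends on the group at this position. No measurement at hand accounts for the step. From the compounds shown here alone, whether an amine, a carboxylic acid or a longer alkoxy chain at this position would lower the number further remains open. Also open, going by these compounds, is whether the same exchange gives a similar step in compound 3.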